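Ethyl in place of the aryl group on the ring nitrogen

The compounds below may be only part of what the source reports. "The series", "measured", "known", "first", "only" and "open" are said of these compounds alone.

Of the compounds shown here, two built on the shared core have been measured in a functional assay on U2OS cells (Homo sapiens) for inhibition, read by CCK-8 assay, with a stated time of 72 h, tested at 1 uM; a higher number here means more inhibition at the concentration tested (going by the name of the read-out), a lower number less inhibition. Compound 1 `COc1ccc(F)cc1N1C(=O)CSC1c1cccc(C(=O)NCCCCc2ccccc2)c1` gives 32% in this assay, and compound 2 `Cc1cccc(N2C(=O)CSC2c2cccc(C(=O)NCCCCc3ccccc3)c2)c1` gives 39%. Going by the values given here, the one step between them is a number 7 percentage points higher from compound 1 to compound 2 (within the scatter), a change of one aryl group for another on the ring nitrogen. It does not separate the two beyond the scatter, so compound 2 stands level with compound 1 on the numbers shown.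

Compound 3 `CCN1C(=O)CSC1c1cccc(C(=O)NCCCCc2ccccc2)c1` is not yet measured. It differs from compound 2 by ethyl in place of 3-methylphenyl on an amide-type nitrogen in a ring. Among the compounds with values here, no measured step bears on such a change: the only step known, from compound 1 to compound 2, swaps one six-membered aromatic ring for another at this position and stays within the scatter, whereas here the ring is removed altogether. The expectation therefore rests on little, and the estimate is a step of a number 9 percentage points lower from compound 2 to compound 3 (within the scatter) in this assay, expected to be small and uncertain in direction. For compound 3 the expected value is 30%, with a range from 10% to 50%.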

Compound 3, a percentage reported as inhibition, at one concentration (the size of the read-out at that concentration, not a potency): 13%
For compound 3 the middle estimate is 17 percentage points above the measured one; the measured number falls inside the stated range.
By their numbers in this assay, from the lowest: compound 3; then compounds 1 and 2 (each within the scatter of the next).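

Taking the aromatic ring off the ring nitrogen has an effect in this assay that exchanging one aryl group for another did not: ethyl in place of 3-methylphenyl gives a number 26 percentage points lower from compound 2 to compound 3 (beyond the scatter) and ethyl in place of 5-fluoro-2-methoxyphenyl gives a number 19 percentage points lower from compound 1 to compound 3 (beyond the scatter) on the same nitrogen. Both steps lie beyond the scatter, so among these three compounds the position is not indifferent to its group, although the two aryl groups of compound 1 and compound 2 cannot be told apart. No measurement shown here explains this loss of inhibition.

The compounds shown leave open whether the aromatic ring itself is what counts or whether a non-aromatic group with as many carbons would serve as well, a question that a cyclohexyl ring or a longer chain such as n-hexyl on this nitrogen would address. They also leave open how a benzyl group, with its aromatic ring set one carbon away from the nitrogen, or a pyridyl ring would compare with the aryl groups of compound 1 and compound 2.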